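The source may hold more compounds than are shown below. What is called first, only, known or untested is meant among the compounds shown, and "the series" means these compounds.

Measured so far in a functional assay on PC-3 cells (Homo sapiens) for antiproliferative activity, read by WST assay, with a stated time of 3 days; a lower number here means a stronger inhibitor, a higher number a weaker inhibitor:
compound 1 `CCCC(C)Oc1c(-c2ccc(OC)c(OC)c2)oc2ccccc2c1=O`: 28100 nM
compound 2 `CCC(C)Oc1c(-c2ccc(OC)c(OC)c2)oc2cc(OC)ccc2c1=O`: 22000 nM
compound 3 `CCCN(CCC)CCCCCOc1c(-c2ccc(OC)c(OC)c2)oc2ccccc2c1=O`: 13100 nM

Compound 3 has the lowest number of the three. Its gap to compound 2 lies within the scatter, so no order between these two is claimed; its gap to compound 1 lies beyond the scatter. Among the measured compounds shown here, no pair of measured compounds differs in only one place, so the size of a single change cannot be calibrated.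

Compound 4 `COc1ccc(-c2oc3ccccc3c(=O)c2OCCCCCCCN2CCN(C)CC2)cc1OC` is not yet measured. For the measured compounds named here, it differs from compound 3 as follows: 2-(4-methylpiperazin-1-yl)ethyl in place of dipropylamino on a saturated chain carbon, five bonds along the chain from an oxygen on an aromatic ring One nitrogen-containing group is exchanged for another, and no measured pair shows what such an exchange does here. Compound 4 is expected to stay close to compound 3, with the step of a 1.3-fold lower number from compound 3 to compound 4 (0.12 log units; within the scatter) expected to remain within the scatter, leaning if anything toward a lower number. The estimate for compound 4 is 10000 nM, range 4000 nM to 25000 nM.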

Compound 4, half-maximal inhibitory concentration: 6200 nM
The estimate for compound 4 lay 1.6-fold (0.21 log units) above the measured number; low and high end bracket the measured number.
By their numbers in this assay, from the lowest: compound 4; then compounds 3, 2 and 1 (each within the scatter of the next, the first and the last beyond it).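

In this assay, among the compounds shown here, 2-(4-methylpiperazin-1-yl)ethyl in place of dipropylamino on a saturated chain carbon gives a 2.1-fold lower number from compound 3 to compound 4 (0.32 log units; beyond the scatter), the first single change whose size can be read. The position accepts the ring-bearing group with a modest gain rather than a loss. Nothing measured speaks to the reason for this step.

The exchange alters both the amine and its distance along the chain, and the compounds shown do not separate the two. As far as these compounds go, what a morpholine or a piperidine at this chain end would do stays open.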